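This account rests on a few compounds, and the source may have more. Where it says the series, first, only, none or still open, it means among the compounds named here.

Compound 1 `Cc1ccc(S(=O)(=O)c2cnc3ccc(Cl)cc3c2N2CCC(C)CC2)cc1F` was examined in an assay on isolated protein for displacement of a labelled ligand from metabotropic glutamate receptor 5 (Homo sapiens), with a stated time of 60 min, tested at 1 uM (a lower number here means less inhibition, a higher number more inhibition at the concentration tested (going by the name of the read-out)), where compound 1 gives 68%. Compound 2 `Cc1ccc(S(=O)(=O)c2cnc3ccc(Cl)cc3c2N2CCC(C)CC2)cc1` differs from compound 1 only by hydrogen in place of fluoro on an aromatic carbon. In this assay compound 2 gives 95%, so the step is a number 27 percentage points higher from compound 1 to compound 2 (beyond the scatter). Compound 3 `CC1CCN(c2c(S(=O)(=O)c3ccc(F)c(F)c3)cnc3c(F)cccc23)CC1` rests on another core; the difference between the cores of compound 1 and compound 3 is not broken down here. In this assay compound 3 gives 93%, a number within the scatter of that of compound 2 and higher than that of compound 1.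

Compound 4 `CC1CCN(c2c(S(=O)(=O)c3cccc(F)c3)cnc3c(F)cccc23)CC1` has not yet been measured. It differs from compound 3 by hydrogen in place of fluoro on an aromatic carbon. For the measured compounds named here, this is the same kind of change as the one from compound 1 to compound 2, but not the same: in compound 1 the leaving fluoro stands ortho to a methyl group and meta to a large group, whereas in compound 3 it stands ortho to a fluoro group and para to a large group. The earlier step was modest but clear. For compound 4 a much smaller step is expected, no change at the digits printed from compound 3 to compound 4 (within the scatter), because compound 3 already gives 93%, leaving little room for the read-out to rise, and the surroundings of the change are not alike. Compound 4 is therefore estimated at about 93%, expected to fall between 82% and 99%.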

Compound 4, a percentage reported as inhibition, at one concentration (the size of the read-out at that concentration, not a potency): 62%
The estimate for compound 4 lay 31 percentage points above the measured number; measured number outside the range, below it.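

In this assay, replacing fluoro by hydrogen on an aromatic carbon, here 3,4-difluorophenyl to 3-fluorophenyl, gave a number 31 percentage points lower from compound 3 to compound 4 (beyond the scatter), so the change did not carry over from one core to the other with its direction intact: the same change on two cores in this assay, a number 27 percentage points higher (beyond the scatter) from compound 1 to compound 2 and a number 31 percentage points lower (beyond the scatter) from compound 3 to compound 4, 58 percentage points apart, beyond the scatter of two such steps. Within these two pairs, then, the same replacement cannot be read as a fixed contribution that may be moved from one compound to another in this series. What this does not show is which difference between the pairs decides the outcome, since they differ both in the core and in the surroundings of the fluoro that leaves, which in compound 3 stands ortho to a fluoro group and para to a large group.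

The compounds shown leave open whether the replacement would run the same way if only the core were exchanged and the groups around the fluoro were kept the same. They also leave open how a chlorine atom, a methoxy group or a nitrile would compare with fluoro and hydrogen at that place on the ring, and how these compounds would rank by potency rather than by inhibition at one concentration.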